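The source may hold more compounds than are shown below. What is called first, only, known or untested is meant among the compounds shown, and "the series" means these compounds.

Measured in a functional assay on the whole organism for antagonist activity, with Mus musculus as the target; a lower number here means that less compound is needed, a higher number that more compound is needed for the effect:
- compound 1 `CCC(=O)N(c1ccc(C)cc1)C1CCCC1N(C)C`: 10 mg/kg; 10 mg/kg (2 entries)
- compound 2 `CCC(=O)N(c1ccc(C(F)(F)F)cc1)C1CCCC1N(C)C`: 25 mg/kg

Within the data shown here, compound 2 holds the only single reading here, since compound 1 has two entries, and compound 2 needs the larger dose of the two. Compound 3 `CCC(=O)N(c1ccc(C(=O)OC)cc1)C1CCCC1N(C)C` keeps the shared core and changes one group, with methoxycarbonyl in place of trifluoromethyl on an aromatic carbon. Among the measured compounds shown here, no measured pair shows what such a swap does, so the data give no size for it. The expected step of no change at the digits printed from compound 2 to compound 3 (within the scatter) in this assay lies within the usual scatter. For compound 3 the estimated dose is 25 mg/kg, with an expected range of 8 mg/kg to 70 mg/kg.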

Compound 3, dose for half-maximal effect: > 50 mg/kg
Compound 3: a limit, no number; the forecaster's own chance of this, stated with the estimate: 15%; middle value at least 2.0-fold (0.30 log units) away from the limit.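

Compound 3 gives > 50 mg/kg in this assay, which is a limit of the assay and not a number. Among these compounds, this is the first step read at this position: methoxycarbonyl in place of trifluoromethyl on an aromatic carbon gives an at least 2.0-fold higher number from compound 2 to compound 3 (0.30 log units; that floor lies within the scatter). The two groups have the same heavy-atom count, but only methoxycarbonyl carries hydrogen-bond acceptors, and this single pair cannot link that difference to the dose.

From the compounds shown here alone, the true size of the step stays open, as the limit gives only its floor. Also open, going by these compounds, is how an amine or a carboxylic acid at this aromatic carbon would compare.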